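Nitro to trifluoromethyl on the sulfonyl aryl ring

This account rests on a few compounds, and the source may have more. Where it says the series, first, only, none or still open, it means among the compounds named here.

Compound 1 `O=C1/C(=C/c2ccncc2)CN(S(=O)(=O)c2ccc([N+](=O)[O-])cc2)C/C1=C\c1ccccc1F` and compound 2 `O=C1/C(=C/c2ccncc2)CN(S(=O)(=O)c2ccc(C(F)(F)F)cc2)C/C1=C\c1ccccc1F` share one core; compound 3 `O=C1/C(=C/c2cccnc2)CN(S(=O)(=O)c2ccc([N+](=O)[O-])cc2)C/C1=C\c1ccccc1C(F)(F)F` and compound 4 `O=C1/C(=C/c2cccnc2)CN(S(=O)(=O)c2ccc(C(F)(F)F)cc2)C/C1=C\c1ccccc1C(F)(F)F` share another, and the difference between the two cores is not broken down here. In a functional assay on SMMC-7721 cells (Homo sapiens) for cytotoxicity, read by MTT assay, with a stated time of 24 h (a higher number here means a weaker inhibitor, a lower number a stronger inhibitor), compound 1 gives 15800 nM, compound 2 gives 11100 nM and compound 3 gives 15900 nM. The change from compound 1 to compound 2 is trifluoromethyl in place of nitro on an aromatic carbon and it made a 1.4-fold lower number from compound 1 to compound 2 (0.15 log units; within the scatter). The same change, (trifluoromethyl in place of nitro on an aromatic carbon), carries compound 3 to compound 4, at the same place on the ring in both pairs. The step expected here is a 1.4-fold lower number from compound 3 to compound 4 (0.14 log units; within the scatter), about the size of a 1.4-fold lower number from compound 1 to compound 2 (0.15 log units; within the scatter), and it rests on that single measured pair. The estimate for compound 4 in this assay is 11500 nM, with a range from 6500 nM to 20000 nM.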

Compound 4, half-maximal inhibitory concentration: 1730 nM
For compound 4 the middle estimate is 6.6-fold (0.82 log units) above the measured one; measured number outside the range, below it.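

In this assay, trifluoromethyl in place of nitro gives a 9.2-fold lower number from compound 3 to compound 4 (0.96 log units; beyond the scatter), so the change does not carry over at one size between the two cores: the same change on two cores in this assay, a 1.4-fold lower number (0.15 log units; within the scatter) from compound 1 to compound 2 and a 9.2-fold lower number (0.96 log units; beyond the scatter) from compound 3 to compound 4, 6.5-fold (0.81 log units) apart, beyond the scatter of two such steps

A step measured on one core is therefore a poor guide to the step on the other in this series. The two pairs do not show which part of the core goes with the difference, and they give no rule for any further core.

As far as these compounds go, it remains open whether an amine or a carboxylic acid in place of nitro, at the same place, would also give steps that differ between these cores. Among the compounds shown here, also open is whether changing only one part of the core would reproduce the larger step.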